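This account rests on a few compounds, and the source may have more. Where it says the series, first, only, none or still open, it means among the compounds named here.

Of the compounds shown here, two of one shared core have been measured for how they affect cultured cells. Compound 1 `CCOC(=O)C1=C(C)N/C(=C/c2cc(C)n(-c3ccc(OC)cc3)c2C)C1=O` was tested in an ADME assay on L6 cells (Rattus norvegicus) for cytotoxicity, read by resazurin assay, with a stated time of 72 h (on this read-out higher numbers stand for an effect only at larger amounts of compound and lower numbers for an effect already at smaller amounts), where compound 1 gives 140000 nM. Compound 2 `CCOC(=O)C1=C(C)N/C(=C/c2cc(C)n(-c3cc(OC)c(OC)c(OO)c3)c2C)C1=O` was tested in the same way, and in this assay compound 2 gives 46000 nM. Of these two numbers, compound 1 holds the higher one, so it is the compound whose effect on the cells appears only at the larger amount; the gap to compound 2 lies beyond the scatter of repeated measurements. The two compounds differ in more than one place, so nothing about any single change can be read from that pair.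

Compound 3 `CCOC(=O)C1=C(C)N/C(=C/c2cc(C)n(-c3cccnc3)c2C)C1=O` has not yet been measured. It differs from compound 1 in one place: pyridin-3-yl in place of 4-methoxyphenyl on an aromatic nitrogen. Going by the values given here, no measured pair shows what this exchange does in this assay. With no guide from the measured compounds, the step of a 1.1-fold higher number from compound 1 to compound 3 (0.03 log units; within the scatter) is expected to stay within the scatter. Compound 3 is therefore estimated to give about 150000 nM in this assay, with a plausible range from 50000 nM to 400000 nM.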

Compound 3, half-maximal effective concentration: 160000 nM
The estimate for compound 3 lay 1.1-fold (0.03 log units) below the measured number; measured number inside the range.
By their numbers in this assay, from the lowest: compound 2; then compounds 1 and 3 (each within the scatter of the next).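

In this assay, going by these compounds alone, the exchange of 4-methoxyphenyl for pyridin-3-yl on an aromatic nitrogen gives a 1.1-fold higher number from compound 1 to compound 3 (0.06 log units; within the scatter) and so offers the first comparison in which only one place differs. Within the data shown here, at this position, a six-membered aromatic ring of carbon only that bears a methoxy group can thus be replaced by a six-membered aromatic ring with one hetero atom, and the two compounds cannot be told apart on this read-out, although this rests on a single pair. No available measurement bears on why compound 1 and compound 3 read so closely alike.

On these data alone, it remains open whether this tolerance extends to quite different groups on the same nitrogen, such as a plain methyl group, a longer alkyl chain, or a phenyl ring carrying an amine or a carboxylic acid. Among these compounds, also unresolved is which feature of compound 2 goes with its lower number, since it differs from compound 1 in more than one place and no single-place pair separates those differences.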